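A Methoxy Group on the Shared Core of Compound 3

A few compounds are considered here, and "the series" means these few. Any claim that something is new, unique, unknown or untested is made for them only; others in the source may bear on it.

Compound 1, `CCn1c(=O)/c(=C2\Sc3ccccc3N2C)s/c1=C\c1ccncc1Nc1ccccc1F`: 300 nM
Compound 2, `CCn1c(=O)/c(=C2\Sc3ccccc3N2C)s/c1=C\c1ccncc1Nc1cc(C)ccc1C`: 1800 nM
Compound 3, `CCn1c(=O)/c(=C2\Sc3ccccc3N2C)s/c1=C\c1ccncc1Nc1ccccc1C`: 470 nM

In a functional assay on CWR22R cells (Homo sapiens) for inhibition (on this read-out higher numbers stand for weaker inhibition and lower numbers for stronger inhibition), compound 3 gives 470 nM, the second highest of the three numbers. The step of a 1.6-fold higher number from compound 1 to compound 3 (0.19 log units; within the scatter) lies within the scatter, so compound 3 and compound 1 cannot be told apart on this read-out, while the step of a 3.8-fold lower number from compound 2 to compound 3 (0.58 log units; beyond the scatter) lies beyond it, as does the step of a 6.0-fold higher number from compound 1 to compound 2 (0.78 log units; beyond the scatter).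

Compound 4, `CCn1c(=O)/c(=C2\Sc3ccc(OC)cc3N2C)s/c1=C\c1ccncc1Nc1ccccc1C`, differs from compound 3 by methoxy in place of hydrogen on an aromatic carbon. All three measured steps alter the group on a nitrogen on an aromatic ring; none alters the fused two-ring part of the shared core, where the methoxy enters. Among the measured compounds shown here, no measured step therefore bears on this change, and the expected step of no change at the digits printed from compound 3 to compound 4 (within the scatter) is one of no change beyond the scatter, with a wide range to reflect that nothing measured informs it. Compound 4 is expected to give 470 nM in this assay, between 160 nM and 1400 nM.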

Compound 4, half-maximal inhibitory concentration: 410 nM
The estimate for compound 4 lay 1.1-fold (0.06 log units) above the measured number, within the range that was stated.
By their numbers in this assay, from the lowest: compounds 1, 4 and 3 (each within the scatter of the next); then compound 2.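

Among the compounds shown here, the step of a 1.1-fold lower number from compound 3 to compound 4 (0.06 log units; within the scatter) is the only measured change on the fused two-ring part of the shared core, and in this assay it lies within the scatter. For the compounds shown here, a methoxy group on this aromatic carbon, meta to a fused ring and para to a fused ring, therefore leaves the number indistinguishable from that with hydrogen, something the earlier steps, all on the group on a nitrogen, could not show. Nothing measured here explains this result.

Methoxy is the only group shown at this position, so it remains open whether an amine, a carboxylic acid or a longer chain such as butoxy on the same carbon would also leave the number in place. Going by these compounds, it also remains open whether methoxy would give the same result alongside the 2-fluorophenyl group of compound 1.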